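Compound 3 and a swap back towards a ring

The source may hold more compounds than are shown below. What is called first, only, known or untested is meant among the compounds shown, and "the series" means these compounds.

Measured in a functional assay on SK-BR-3 cells (Homo sapiens) for antiproliferative activity; on this read-out lower numbers stand for stronger inhibition and higher numbers for weaker inhibition:
- compound 1 `CC(C)=CCc1cc(C(=O)Nc2cc3ccc(OCCCN4CCCCC4)c(C)c3oc2=O)ccc1O`: > 50000 nM
- compound 2 `CC(C)=CCc1cc(C(=O)Nc2cc3ccc(OCCCNCC(=O)O)c(C)c3oc2=O)ccc1O`: 7570 nM
- compound 3 `CC(C)=CCc1cc(C(=O)Nc2cc3ccc(OCCCNCC(N)=O)c(C)c3oc2=O)ccc1O`: 2290 nM

The entry for compound 1 is a limit of the assay, not a number: the limit of > 50000 nM in this assay, at which 1 of the 3 values shown sits. Compound 3 has the lower of the two true numbers, and a 3.3-fold lower number from compound 2 to compound 3 (0.52 log units; beyond the scatter) separates it from compound 2.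

Compound 4 `CC(C)=CCc1cc(C(=O)Nc2cc3ccc(OCCCN(C)C4CCCCC4)c(C)c3oc2=O)ccc1O` changes one group of compound 3: cyclohexyl(methyl)amino in place of (carbamoylmethyl)amino on a saturated chain carbon, three bonds along the chain from an oxygen on an aromatic ring. Here cyclohexyl(methyl)amino takes the place of (carbamoylmethyl)amino on a saturated chain carbon, three bonds along the chain from an oxygen on an aromatic ring.

The closest guides are the steps away from the piperidin-1-yl group of compound 1: an at least 21-fold lower number from compound 1 to compound 3 (1.33 log units; beyond the scatter), and an at least 6.6-fold lower number from compound 1 to compound 2 (0.81 log units; beyond the scatter). Compound 4 returns to a ring-bearing amino group, so those steps are expected to run largely in reverse, although cyclohexyl(methyl)amino has not itself been measured. A clearly higher number is therefore expected, with an estimated 8.7-fold higher number from compound 3 to compound 4 (0.94 log units; beyond the scatter). The estimate for compound 4 is 20000 nM, within an expected range of 6000 nM to 50000 nM.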

Compound 4, half-maximal inhibitory concentration: 970 nM
Compound 4: the middle estimate sits 21-fold (1.31 log units) above what was measured; the whole stated range lies above it.
By their numbers in this assay, from the lowest: compound 4; then compound 3; then compound 2. At a limit, above all of these: compound 1.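

For the compounds shown here, compound 4 shows that a ring-bearing amine on this chain carbon need not weaken the result: in this assay, cyclohexyl(methyl)amino gives a 2.4-fold lower number from compound 3 to compound 4 (0.37 log units; beyond the scatter) and also a 7.8-fold lower number from compound 2 to compound 4 (0.89 log units; beyond the scatter), the lowest true number so far. The earlier compounds paired a ring only with the poorest result, whereas piperidin-1-yl and cyclohexyl(methyl)amino now stand at opposite ends of this series, so the presence of a ring does not decide the outcome among these compounds. The change from piperidin-1-yl gives an at least 51-fold lower number from compound 1 to compound 4 (1.71 log units; beyond the scatter), but that step starts from a limit for compound 1, not a number: the limit of > 50000 nM in this assay, at which 1 of the 4 values shown sits.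

The compounds shown do not separate the contribution of the cyclohexyl ring from that of the methyl on the same nitrogen. They also leave open how a cyclohexylamino group, a dimethylamino group or a longer chain would compare.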